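Pyridin-2-yl in Place of Fluorophenyl: Expected Maximal Response

A few compounds are considered here, and "the series" means these few. Any claim that something is new, unique, unknown or untested is made for them only; others in the source may bear on it.

Measured so far in an in vitro functional assay on HEK285-7 cells for antagonist activity at prostaglandin D2 receptor 2 (Homo sapiens), read by BRET and beta-arrestin recruitment; on this read-out lower numbers stand for smaller maximal responses and higher numbers for larger maximal responses:
Compound 1, `O=C(O)Cc1sc(C(c2ccc(F)cc2)c2ccc(F)cc2)nc1-c1ccc(Cl)cc1`, gives 80%.
Compound 2, `CCC(c1ccccc1)c1nc(-c2ccc(Cl)cc2)c(CC(=O)O)s1`, gives 50%.
Compound 3, `O=C(O)Cc1sc(C(c2ccccc2)c2ccc(F)cc2)nc1-c1ccc(Cl)cc1`, gives 80%.

On these numbers compound 3 stands level with compound 1, the two together the highest of the three, and well clear of compound 2. Dropping the fluoro gave no change at the digits printed from compound 1 to compound 3 (within the scatter). Replacing ethyl by an aromatic ring gave a number 30 percentage points higher from compound 2 to compound 3 (beyond the scatter).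

Compound 4, `O=C(O)Cc1sc(C(c2ccccc2)c2ccccn2)nc1-c1ccc(Cl)cc1`, is not yet measured in this assay. Its difference from compound 3 is pyridin-2-yl in place of 4-fluorophenyl on a saturated chain carbon bound to two aromatic carbons.

Among the measured compounds shown here, two measured steps bear on this. The first, no change at the digits printed from compound 1 to compound 3 (within the scatter), shows that a small edit on the aromatic ring at this position leaves the maximal response unchanged. The second, a number 30 percentage points higher from compound 2 to compound 3 (beyond the scatter), shows that the presence of an aromatic ring at this position, rather than a short chain, is what lifts the response. Compound 4 keeps an aromatic ring there, so the expected step in this assay is small, a number 5 percentage points lower from compound 3 to compound 4 (within the scatter), with a slight lean downward to allow for the ring nitrogen. Compound 4 is therefore expected to give about 75%, with a range from 55% to 95%.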

Compound 4, largest response reached (reported as efficacy), in percent of the reference or control that the assay uses: 55%
Estimate against measurement, compound 4: 20 percentage points above, and the stated range covers the measured number.
By their numbers in this assay, from the lowest: compounds 2 and 4 (each within the scatter of the next); then compounds 1 and 3 (each within the scatter of the next).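

In this assay, keeping an aromatic ring at this position turns out not to be enough to keep the maximal response, since pyridin-2-yl in place of 4-fluorophenyl gives a number 25 percentage points lower from compound 3 to compound 4 (beyond the scatter) and so goes beyond the scatter, which the earlier ring edit did not do. The comparison with the short chain changes as well: the step to pyridin-2-yl from ethyl is a number 5 percentage points higher from compound 2 to compound 4 (within the scatter) and so does not separate the two groups, which means that this position responds to which ring is present, and not simply to whether a ring is there at all. The change swaps a carbon-only ring for one with a ring nitrogen and adds a hydrogen-bond acceptor to the count, but no measurement here tells why the response falls.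

The compounds shown leave open whether pyridin-3-yl, pyridin-4-yl or a pyrimidinyl ring would group with compound 3 or with compound 4. They also leave open whether a longer chain such as propyl or butyl would sit level with ethyl, and whether a ring carrying an amine or a methoxy group could hold the higher response.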